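Adding a Bromine to a Chromone Phenethyl Ether

This account rests on a few compounds, and the source may have more. Where it says the series, first, only, none or still open, it means among the compounds named here.

The starting point is compound 1, `O=c1ccoc2ccc(OCCc3ccccc3)cc12`, tested in an assay on microsomes for inhibition of Amine oxidase [flavin-containing] B (Homo sapiens), read by fluorescence and spectrophotometry, with a stated time of 20 min (on this read-out higher numbers stand for weaker inhibition and lower numbers for stronger inhibition), where compound 1 gives 21 nM. Two related compounds have also been measured. Compound 2, `O=c1ccoc2ccc(OCc3cccc(Br)c3)cc12`, gives 2 nM in this assay, and compound 3, `O=c1ccoc2ccc(OCc3ccc(Br)cc3)cc12`, gives 3.3 nM. Among these three numbers compound 1 stands highest, meaning it is the weakest inhibitor of the set; its gap to compound 3 and its larger gap to compound 2 both lie beyond the usual scatter, while compounds 2 and 3 sit within the scatter of each other and cannot be ordered.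

The next compound, compound 4, is `O=c1ccoc2ccc(OCCc3ccc(Br)cc3)cc12`. It differs from compound 1 only in the change (bromo in place of hydrogen on an aromatic carbon), which, cut one bond further out, reads phenyl to 4-bromophenyl, the bromine sitting on an aromatic carbon para to a large group.

Within the data shown here, no directly comparable pair of measured compounds isolates this change. Compounds 2 and 3, which carry bromine, both give lower numbers than compound 1, but they also differ from compound 1 in the linker, so the bromine alone is not separated out. The step from compound 1 to compound 4 is expected to be a 2.6-fold lower number from compound 1 to compound 4 (0.42 log units; beyond the scatter), a moderate gain in inhibition. Compound 4 is therefore estimated at 8 nM, with a likely range from 3 nM to 25 nM.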

Compound 4, half-maximal inhibitory concentration: 27 nM
Compound 4: the middle estimate sits 3.4-fold (0.53 log units) below what was measured; measured number above the stated range.
By their numbers in this assay, from the lowest: compounds 2 and 3 (each within the scatter of the next); then compounds 1 and 4 (each within the scatter of the next).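

Going from phenyl to 4-bromophenyl, with the bromine para to a large group, gives a 1.3-fold higher number from compound 1 to compound 4 (0.11 log units; within the scatter) in this assay, so on the linker of compound 1 this change leaves inhibition unchanged within the scatter. This step isolates the bromine, and it shows that bromine alone does not bring the number down on this linker. Compound 3 and compound 4 carry the same 4-bromophenyl group and differ only in linker length, yet compound 3 gives 3.3 nM and compound 4 gives 27 nM, so the effect of the bromine cannot be assumed to carry over from one linker to the other, and the data shown offer no explanation for the flat step.

The compounds shown leave open what the unsubstituted phenyl ring gives on the shorter linker of compound 3, which would show whether bromine matters there. They also leave open whether a different group at this position, such as an amine or a carboxylic acid, or a longer chain in place of the linker of compound 4, would move the number in either direction.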